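This account rests on a few compounds, and the source may have more. Where it says the series, first, only, none or still open, it means among the compounds named here.

Measured in a functional assay on Hep cells (Homo sapiens) for cytotoxicity, read by sulforhodamine B assay, with a stated time of 48 h; a lower number here means a stronger inhibitor, a higher number a weaker inhibitor:
- compound 1 `C=CCOc1cc(Br)ccc1C(=O)c1cccnc1`: > 100000 nM
- compound 2 `O=C(c1cccnc1)c1cc(F)ccc1O`: 12000 nM
- compound 3 `O=C(c1cccnc1)c1ccccc1O`: 31000 nM
- compound 4 `O=C(c1cccnc1)c1cccc(Cl)c1O`: not yet measured

Compound 1 gives > 100000 nM, which is a limit of the assay and not a number. It differs from the others in more than one place, so it offers no clean single-change comparison.

Compound 3, at 31000 nM, has the higher of the two true numbers, and compound 2 stands at 12000 nM. Compound 3 is thus the weaker inhibitor of this pair in this assay.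

The next change is chloro in place of hydrogen on an aromatic carbon, ortho to a hydroxy group.

For the measured compounds named here, only one measured step bears on this change: a 2.6-fold higher number from compound 2 to compound 3 (0.41 log units; beyond the scatter), with hydrogen in place of fluoro. Read backwards, a halogen in place of hydrogen went with a lower number in that pair. This is only a rough guide, as the fluoro of compound 2 is a different halogen and sits at a different place from the new chloro.

A similar modest move toward a lower number is therefore expected, and the estimated step is a 2.2-fold lower number from compound 3 to compound 4 (0.35 log units; beyond the scatter). The estimate for compound 4 is 14000 nM, with an expected range from 5000 nM to 40000 nM.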

Compound 4, half-maximal inhibitory concentration: 28000 nM
The estimate for compound 4 lay 2.0-fold (0.30 log units) below the measured number, and the stated range covers the measured number.
By their numbers in this assay, from the lowest: compound 2; then compounds 4 and 3 (each within the scatter of the next). At a limit, above all of these: compound 1.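

In this assay, chloro in place of hydrogen on an aromatic carbon, ortho to a hydroxy group, gives a 1.1-fold lower number from compound 3 to compound 4 (0.04 log units; within the scatter) and so leaves the number effectively unchanged at this position. For the compounds shown here, the only earlier single-change comparison was a 2.6-fold higher number from compound 2 to compound 3 (0.41 log units; beyond the scatter) with hydrogen in place of fluoro, and read backwards it linked a halogen with a lower number; the new step shows that this link does not carry over to chloro at this place, though two steps are too few to separate the effect of the halogen from that of its place. No measurement shown explains why the two steps differ.

The compounds shown leave open whether a different group at this same place, such as a methyl, a methoxy or an amine, would shift the number beyond the scatter. They also leave open whether chloro at the place that fluoro holds in compound 2 would go with a lower number, which would help show whether the place or the halogen matters more.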